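The source may report more compounds than this note shows. Statements on the series, on what has been measured and on what is new or still open speak of the compounds shown alone.

In a functional assay on stomach for antagonist activity at Gastrin/cholecystokinin type B receptor (Rattus norvegicus) (on this read-out lower numbers stand for tighter binding and higher numbers for weaker binding), the measured compounds stand as follows:
compound 1 `O=C(CN1N=C(C2CCCCC2)c2ccccc2N(CC(=O)C2CCCC2)C1=O)Nc1cccc(C(=O)O)c1` gives 1.95 nM
compound 2 `CC(C)(C)C(=O)CN1C(=O)N(CC(=O)Nc2cccc(-c3nc(=O)o[nH]3)c2)N=C(C2CCCCC2)c2ccccc21` gives 9.55 nM

Compound 2 carries the higher of these two numbers; compound 1, its nearest neighbour, sits clearly lower, beyond the scatter. Compound 3 `CN(c1cccc(NC(=O)CN2N=C(C3CCCCC3)c3ccccc3N(CC(=O)C(C)(C)C)C2=O)c1)c1nn[nH]n1` keeps the core of compound 2 and differs only in one group on the aromatic carbon of the six-membered carbon ring: a group of 7 heavy atoms (2 carbon, 5 nitrogen; one five-membered aromatic ring with 4 hetero atoms) in place of a group of 6 heavy atoms (2 carbon, 2 nitrogen, 2 oxygen; one five-membered aromatic ring with 3 hetero atoms), on an aromatic carbon. For the measured compounds named here, no single-change step has been measured in this set, so the weight of such a swap is not known from these data. The step expected here is a 1.3-fold higher number from compound 2 to compound 3 (0.10 log units; within the scatter), that is, none beyond the scatter in this assay. Compound 3 is estimated to give 12 nM, with a range of 4 nM to 40 nM.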

Compound 3, dissociation constant: 24 nM
Compound 3: middle estimate off by 2.0-fold (0.30 log units), on the low side; low and high end bracket the measured number.
By their numbers in this assay, from the lowest: compound 1; then compound 2; then compound 3.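

In this assay, for the compounds shown here, the aromatic carbon meta to a large group gives the first single-change reading: placing (2H-tetrazol-5-yl)(methyl)amino there brings a 2.5-fold higher number from compound 2 to compound 3 (0.40 log units; beyond the scatter) and counts as a modest step. The position therefore responds to this swap, though only modestly. Nothing measured here bears on what lies behind the step.

Still open, on these data alone, is what the methyl contributes, as a plain amino link would show. A sulfonamide at this position, and the same swap on the core of compound 1, also remain to be read.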